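A Pyridone Enters Where a Fluoropyridine Leaves

A few compounds are considered here, and "the series" means these few. Any claim that something is new, unique, unknown or untested is made for them only; others in the source may bear on it.

Compound 1 `CCCCc1nc(=O)c(S(=O)(=O)c2ccc(-c3cccnc3)cc2)c(O)n1-c1c(OC)cccc1OC` and compound 2 `CCCCc1[nH]c(=O)c(S(=O)(=O)c2ccc(-c3ccncc3C)cc2)c(O)c1-c1c(OC)cccc1OC` share their core with the two compounds that follow, and both carry a measured result. In an ADME assay on microsomes from liver (Homo sapiens) for metabolic stability, using NADPH, with a stated time of 10 min (on this read-out lower numbers stand for a less stable compound and higher numbers for a more stable compound), compound 1 gives 88%, and in this assay compound 2 gives 80%. Compound 3 `CCCCc1[nH]c(=O)c(S(=O)(=O)c2ccc(-c3ccc(F)nc3)cc2)c(O)c1-c1c(OC)cccc1OC` in this assay gives "not determined" (no result reported), so it stands without a number of its own, and the only reference points around it are the values of compound 1 and compound 2. Compound 4 `CCCCc1[nH]c(=O)c(S(=O)(=O)c2ccc(-n3cc(Cl)ccc3=O)cc2)c(O)c1-c1c(OC)cccc1OC` has not yet been measured. It differs from compound 3 in one place: a group of 8 heavy atoms (5 carbon, 1 nitrogen, 1 oxygen, 1 chlorine; one six-membered aromatic ring with 1 hetero atom) in place of a group of 7 heavy atoms (5 carbon, 1 nitrogen, 1 fluorine; one six-membered aromatic ring with 1 hetero atom), on an aromatic carbon. Among the measured compounds shown here, no measured pair of compounds spans this exchange, so neither the size nor the direction of the step in this assay can be read from the data. The expectation is a step that stays within the scatter, or at most a modest move downward, since nothing in the data points to a larger shift. That expectation rests on compound 1 with 88% and on compound 2 with 80%, which frame the range so far. Compound 4 is therefore expected to give about 75% in this assay, estimated to fall between 55% and 92%.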

Compound 4, percent of the compound remaining: 97%
Compound 4: middle estimate off by 22 percentage points, on the low side, and the stated range ends below it.
By their numbers in this assay, from the lowest: compounds 2, 1 and 4 (each within the scatter of the next, the first and the last beyond it).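

At the aromatic carbon para to a large group, this assay now gives a first readable step: the chlorine-bearing group of compound 4 replaces the group of 7 heavy atoms in compound 2, and the read-out shows a number 17 percentage points higher from compound 2 to compound 4 (beyond the scatter) as a modest move beyond the scatter. Before this result, no pair of compounds differing in one place had been available, so the position had no measured step at all. It now appears that a group with oxygen and chlorine, and with a double bond outside the aromatic ring, can stand here without any loss on this read-out, whereas the opening estimate had leaned the other way. Compound 3 has no result, so the steps that would start from it cannot be read. Nothing measured here accounts for the rise.

From the compounds shown here alone, it remains open whether the chlorine or the rest of the entering group carries this step, and how an amine, a carboxylic acid or a longer chain on the same ring would read. Going by these compounds, it also remains open whether the step would hold in the company of other parts of the molecule, or in any read-out other than this one.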